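Anilide exchange in the shared core: compound 1 toward compound 4

A few compounds are considered here, and "the series" means these few. Any claim that something is new, unique, unknown or untested is made for them only; others in the source may bear on it.

In a functional assay on A549 cells (Homo sapiens) for cytotoxicity, read by MTT assay, with a stated time of 72 h (on this read-out higher numbers stand for weaker inhibition and lower numbers for stronger inhibition), compound 1 `O=C(CN1CCN(c2nnc(Cc3ccncc3)c3ccccc23)CC1)Nc1ccc(F)c(Cl)c1` gives 12300 nM, the highest of the two numbers in the series. Compound 2 `O=C(CN1CCN(c2nnc(Cc3ccccc3)c3ccccc23)CC1)Nc1ccc(F)c(C(F)(F)F)c1` sits at 2480 nM, a gap beyond the scatter, while compound 3 `Cc1ccccc1NC(=O)CN1CCN(c2nnc(Cc3ccccc3)c3ccccc23)CC1` is recorded as "not active" (no number reported), without a number. Compound 4 `Cc1ccc(F)cc1NC(=O)CN1CCN(c2nnc(Cc3ccncc3)c3ccccc23)CC1` is compound 1 with 5-fluoro-2-methylphenyl in place of 3-chloro-4-fluorophenyl on an amide-type nitrogen. Among the measured compounds shown here, no measured pair shows this exchange directly, so its size is unknown; the only anchor is compound 3, whose anilide is methyl-bearing and which gave no number. The expectation is therefore a step from compound 1 to compound 4 of about a 2.0-fold higher number from compound 1 to compound 4 (0.31 log units; beyond the scatter), toward weaker inhibition, with a real chance of a limit only. Compound 4 is estimated at 25000 nM, between 8000 nM and 80000 nM.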

Compound 4, half-maximal inhibitory concentration: 38900 nM
For compound 4 the middle estimate is 1.6-fold (0.19 log units) below the measured one; low and high end bracket the measured number.
By their numbers in this assay, from the lowest: compound 2; then compound 1; then compound 4.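

Among the compounds shown here, the first direct reading at this position comes from this assay: 5-fluoro-2-methylphenyl in place of 3-chloro-4-fluorophenyl on the amide-type nitrogen gives a 3.2-fold higher number from compound 1 to compound 4 (0.50 log units; beyond the scatter), toward weaker inhibition. Changing only the groups on the phenyl ring, with the heavy-atom count unchanged, moves the number beyond the scatter. Nothing at hand accounts for the shift.

For the compounds shown here, the single step cannot separate the contributions of the chlorine, the methyl and the moved fluorine. Going by these compounds, how an amine or a carboxylic acid on this phenyl ring would read remains open.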